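Cytotoxicity of Four Related Compounds on Vero Cells

The source may hold more compounds than are shown below. What is called first, only, known or untested is meant among the compounds shown, and "the series" means these compounds.

Compound 1 `O=C1CSC(c2cccc(Cl)c2)N1CCN1CCCCC1` gives 45% in an ADME assay on Vero cells (Chlorocebus sabaeus) for cytotoxicity, read by neutral red uptake, tested at 394 ug/mL; on this read-out higher numbers stand for a weaker effect at the one concentration tested and lower numbers for a stronger effect.
Compound 2 `O=C1CSC(c2cccc(O)c2)N1CCN1CCCCC1` gives 100% in this assay.
Compound 3 `O=C1CSC(c2ccc([N+](=O)[O-])cc2)N1CCN1CCCCC1` gives 66% in this assay.

Among these three numbers compound 3 stands second highest. Its nearest neighbour is compound 1, whose number lies lower, beyond the scatter; furthest away is compound 2, whose number lies higher, again beyond the scatter. Going by the values given here, only one step between measured compounds that differ in a single place is known: a number 55 percentage points higher from compound 1 to compound 2 (beyond the scatter), hydroxy in place of chloro on an aromatic carbon.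

Compound 4 `Cc1ccc(C2SCC(=O)N2CCN2CCCCC2)cc1` has not yet been measured in this assay. It differs from compound 3 as follows: methyl in place of nitro on an aromatic carbon. Among the compounds with values here, no measured step covers methyl or nitro, so nothing bears directly on this change. The step from compound 1 to compound 2 does show that a single change on an aromatic carbon of this core can move the read-out by a large amount, so a step beyond the scatter is plausible here too, though its direction is uncertain. The estimated step of a number 16 percentage points lower from compound 3 to compound 4 (beyond the scatter) is therefore given as a moderate decrease with a wide range. Compound 4 is expected to give about 50%, between 25% and 80%.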

Compound 4, a percentage reported as activity, at one concentration (the size of the read-out at that concentration, not a potency): 51%
Compound 4: middle estimate off by 1 percentage points, on the low side; the measured number falls inside the stated range.
By their numbers in this assay, from the lowest: compounds 1 and 4 (each within the scatter of the next); then compound 3; then compound 2.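

Methyl in place of nitro, on an aromatic carbon para to a large group, gives a number 15 percentage points lower from compound 3 to compound 4 (beyond the scatter) in this assay, so a single change at this position also moves the read-out beyond the scatter, though only modestly. 4-Methylphenyl in place of 3-hydroxyphenyl gives a number 49 percentage points lower from compound 2 to compound 4 (beyond the scatter), while 4-methylphenyl in place of 3-chlorophenyl gives a number 6 percentage points higher from compound 1 to compound 4 (within the scatter). The aryl group of compound 4 therefore cannot be told apart from that of compound 1 on this read-out, and compound 2 remains well apart from both. No measurement of any property of these groups is available to account for these numbers.

The compounds shown leave open whether the read-out follows the group or its place on the aromatic ring, since nitro and methyl appear only para to a large group, while chloro and hydroxy appear only in 3-chlorophenyl and 3-hydroxyphenyl. They also leave open how an amine or a carboxylic acid at this position, or a longer chain in place of methyl, would read.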